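Working notes: from compound 3 to compound 4

The compounds below may be only part of what the source reports. "The series", "measured", "known", "first", "only" and "open" are said of these compounds alone.

Measured so far:
compound 1, `N#Cc1ccccc1N1CCN(Cc2nc3ccccc3[nH]2)CC1`, 46%
compound 2, `Fc1cccnc1N1CCN(Cc2nc3ccccc3[nH]2)CC1`, 27%
compound 3, `N#Cc1cccnc1N1CCN(Cc2nc3ccccc3[nH]2)CC1`, 50%

The three share one core and differ only in the aryl group on the amine nitrogen of the ring. In an assay on HEK293 cells with D(4) dopamine receptor (Homo sapiens) as the target, read by FLIPR (a lower number here means a smaller maximal response, a higher number a larger maximal response), compound 3 has the highest of the three numbers, but compound 1 sits within the scatter of it, so no order between those two can be claimed; only compound 2 lies clearly lower. The measured steps read a number 19 percentage points lower from compound 1 to compound 2 (beyond the scatter), a number 4 percentage points higher from compound 1 to compound 3 (within the scatter) and a number 23 percentage points higher from compound 2 to compound 3 (beyond the scatter).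

Compound 4, `CS(=O)(=O)c1cccnc1N1CCN(Cc2nc3ccccc3[nH]2)CC1`, differs from compound 3 thus: methylsulfonyl in place of cyano on an aromatic carbon. Going by the values given here, no measured step exchanges cyano for methylsulfonyl. Among the compounds with values here, the one step at this same carbon, a number 23 percentage points higher from compound 2 to compound 3 (beyond the scatter), shows that a change of the group here can move the maximal response by a modest amount. Going by these compounds, the direction for compound 4 stays open, since neither group of that step is methylsulfonyl. A modest step downward, or none beyond the scatter, is expected for compound 4, that is a number 10 percentage points lower from compound 3 to compound 4 (within the scatter). The estimate for compound 4 is 40%, with a range from 20% to 60%.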

Compound 4, largest response reached (reported as efficacy), in percent of the reference or control that the assay uses: 27%
Estimate against measurement, compound 4: 13 percentage points above; the range from low to high includes it.
By their numbers in this assay, from the lowest: compounds 2 and 4 (each within the scatter of the next); then compounds 1 and 3 (each within the scatter of the next).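

In this assay, going by these compounds alone, this is the first direct exchange of cyano for methylsulfonyl on this aromatic carbon, ortho to a large group, and it settles the direction downward (a number 23 percentage points lower from compound 3 to compound 4 (beyond the scatter)). Against fluoro, the same group shows no separable difference (no change at the digits printed from compound 2 to compound 4 (within the scatter)), so among the three groups seen at this carbon only cyano, in compound 3, stands clearly higher, while compounds 2 and 4 cannot be ordered. Nothing at hand speaks to why the maximal response falls with this exchange.

The compounds shown leave open whether another group on this carbon, such as an amine, a methoxy group or a carboxylic acid, would stay at the level of cyano or fall to the level of fluoro and methylsulfonyl. They also leave open whether methylsulfonyl in place of cyano would give a similar step on the 2-cyanophenyl group of compound 1, where the six-membered aromatic ring has no ring nitrogen.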